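The compounds below may be only part of what the source reports. "The series", "measured", "known", "first", "only" and "open" are said of these compounds alone.

Compound 2 `CCNc1cc(-c2ccc(NC(=O)Nc3ccc(OC)cc3)cc2C(F)(F)F)ccn1` gives 62.1% in an assay on isolated protein for inhibition of serine/threonine-protein kinase PLK1 (Homo sapiens), read by radiometric assay and 33P incorporation, with a stated time of 40 min, tested at 20 uM, in the presence of a further agent that is not named here; on this read-out lower numbers stand for less inhibition and higher numbers for more inhibition at the one concentration tested (going by the name of the read-out). Among the three measured compounds it has the highest number, though its companion compound 3 `CCNc1cc(-c2ccc(NC(=O)Nc3cccc4ccccc34)cc2C(F)(F)F)ccn1` with 54.1% sits close: the step of a number 8 percentage points lower from compound 2 to compound 3 (within the scatter) falls within the scatter, so no order can be read between those two. Compound 1 `CCNc1cc(-c2ccc(NC(=O)Nc3ccc(OC)cc3)cc2C)ccn1` gives 45.8%, and the step of a number 16.3 percentage points higher from compound 1 to compound 2 (beyond the scatter) is beyond the scatter.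

Compound 4 `CCNc1cc(-c2ccc(NC(=O)Nc3ccc(OC)cc3)cc2OC)ccn1` differs from compound 2 in one place: methoxy in place of trifluoromethyl on an aromatic carbon. Within the data shown here, of the measured steps, only the one from compound 1 to compound 2 concerns the same aromatic carbon, where trifluoromethyl in place of methyl brought a modest rise; the step from compound 2 to compound 3 touches another part of the molecule and does not bear on this exchange. Methoxy is neither of the two groups already tried there, so the expectation is loose: removing the trifluoromethyl is expected to give back roughly the gain seen from compound 1 to compound 2, as a step of a number 16.1 percentage points lower from compound 2 to compound 4 (beyond the scatter). Compound 4 is therefore estimated at 46%, within a range from 26% to 64%.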

Compound 4, a percentage reported as inhibition, at one concentration (the size of the read-out at that concentration, not a potency): 31.1%
For compound 4 the middle estimate is 14.9 percentage points above the measured one; measured number inside the range.
By their numbers in this assay, from the lowest: compound 4; then compounds 1, 3 and 2 (each within the scatter of the next, the first and the last beyond it).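

Methoxy at this aromatic carbon does more than undo the gain from trifluoromethyl, as this assay shows a number 31 percentage points lower from compound 2 to compound 4 (beyond the scatter) and also a number 14.7 percentage points lower from compound 1 to compound 4 (beyond the scatter). Compound 4 therefore falls below both compound 1 and compound 2, and with all three steps at this carbon beyond the scatter, the groups rank in the order trifluoromethyl, methyl, methoxy. Nothing given here explains this order.

The compounds shown leave open where a chlorine atom, a nitrile or a longer alkoxy chain would fall in this order at the same carbon. They also leave open whether the order would hold with naphthalen-1-yl in place of 4-methoxyphenyl on the amide-type nitrogen, since only trifluoromethyl has been paired with that group here.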